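This account rests on a few compounds, and the source may have more. Where it says the series, first, only, none or still open, it means among the compounds named here.

Compound 2 `COc1cc2ncnc(-n3nc(C4CCCCC4)nc3N)c2cc1OC` stands at the weak end of what has been measured. In an assay on MCF7 cells for inhibition of Serine-protein kinase ATM (Homo sapiens), read by immunofluorescence, with a stated time of 1 h (on this read-out higher numbers stand for weaker inhibition and lower numbers for stronger inhibition), compound 2 gives only a limit of the assay, > 40000 nM. Compound 1 `COc1cc2ncnc(-n3nc(-c4cccnc4)nc3N)c2cc1OC` gives 15000 nM in this assay. For the measured compounds named here, the single measured step, an at least 2.6-fold higher number from compound 1 to compound 2 (0.42 log units; beyond the scatter), runs toward weaker inhibition and ends at the limit of > 40000 nM in this assay, at which 1 of the 2 values shown sits. Compound 3 `COc1cc2ncnc(-n3nc(N)nc3N)c2cc1OC` differs from compound 2 by amino in place of cyclohexyl on an aromatic carbon. Going by the values given here, no measured step covers this change, so its direction is not known from the data. Compound 3 is therefore expected to remain near the limit, with an estimate of 40000 nM, between 12000 nM and 130000 nM. The expected step is a number no higher from compound 2 to compound 3 (the limit leaves the size open).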

Compound 3, half-maximal inhibitory concentration: > 40000 nM
Compound 3: no number, only a limit; the forecaster's own chance of this, stated with the estimate: 60%; the middle value lies on the limit itself.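

Amino on this aromatic carbon, like cyclohexyl, falls short of pyridin-3-yl, with an at least 2.6-fold higher number from compound 1 to compound 3 (0.42 log units; beyond the scatter) in this assay. The step between compound 2 and compound 3 cannot be read, since both values are limits. Of the three groups shown at this position, only pyridin-3-yl gives a number rather than a limit: the limit of > 40000 nM in this assay, at which 2 of the 3 values shown sit.

Going by these compounds, what stays open is whether the ring nitrogen of pyridin-3-yl matters, which a phenyl ring here would address. On these data alone, whether a longer chain, such as a substituted amine, would return a readable number also remains unknown.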